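A few compounds are considered here, and "the series" means these few. Any claim that something is new, unique, unknown or untested is made for them only; others in the source may bear on it.

Measured so far:
- compound 1, `CCCCC/C=C/CCCCCCCCCC1(C(=O)OC)CO1`: 20000 nM
- compound 2, `CCCCCCCCCCCCCCC1(C(=O)OCC(O)CO)CO1`: 16000 nM
- compound 3, `CCCCCCCCCCCCCCC1(C(=O)OC)CO1`: 2000 nM

In a functional assay for inhibition, with Rattus norvegicus as the target (on this read-out higher numbers stand for weaker inhibition and lower numbers for stronger inhibition), compound 1 gives the highest number of the three, that is, the weakest inhibition; compound 2 sits within the scatter of it, while compound 3 lies well beyond the scatter with a markedly lower number. The step from compound 1 to compound 3, a 10-fold lower number from compound 1 to compound 3 (1.00 log units; beyond the scatter), shows that shortening the long chain and removing its double bond goes with clearly stronger inhibition. The step of an 8.0-fold lower number from compound 2 to compound 3 (0.90 log units; beyond the scatter) concerns the ester end instead and does not bear on the chain.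

Compound 4, `CCCCCCCCCCCCC1(C(=O)OC)CO1`, differs from compound 1 in one place: propyl in place of hept-1-en-1-yl on a saturated chain carbon, nine bonds along the chain from a saturated ring carbon. This is the same kind of change as from compound 1 to compound 3, only cut shorter still. Within the data shown here, the one directly relevant step is modest but beyond the scatter, so a step of similar size and in the same direction is expected in this assay, though a shorter chain than that of compound 3 may not carry the full benefit. For compound 4 the estimated value is 3500 nM, with a range from 1200 nM to 12000 nM, which would correspond to an expected step of a 5.7-fold lower number from compound 1 to compound 4 (0.76 log units; beyond the scatter).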

Compound 4, half-maximal inhibitory concentration: 15000 nM
The estimate for compound 4 lay 4.3-fold (0.63 log units) below the measured number, and the stated range ends below it.
By their numbers in this assay, from the lowest: compound 3; then compounds 4, 2 and 1 (each within the scatter of the next).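

In this assay, putting propyl in place of hept-1-en-1-yl, nine bonds along the chain from a saturated ring carbon, gives a 1.3-fold lower number from compound 1 to compound 4 (0.12 log units; within the scatter), so removing the double bond and cutting the chain do not by themselves bring stronger inhibition. Hydrogen in place of ethyl on a saturated chain carbon gives a 7.5-fold higher number from compound 3 to compound 4 (0.88 log units; beyond the scatter), so the gain seen with pentyl is lost with propyl, and among these compounds the result depends on the exact length of the saturated chain. No available measurement explains why this small change matters so much.

Butyl, hexyl and heptyl at this place would show whether pentyl is a narrow optimum or part of a broader trend. A saturated heptyl group would also separate the effect of the double bond from that of chain length.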